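A few compounds are considered here, and "the series" means these few. Any claim that something is new, unique, unknown or untested is made for them only; others in the source may bear on it.

Working notes on the series. Of the compounds shown here, three have been measured in a functional assay on Z-138 cells (Homo sapiens) for antiproliferative activity, with a stated time of 72 h; a higher number here means a weaker inhibitor, a lower number a stronger inhibitor. Compound 1 `CCCC#Cc1cc([C@@H]2O[C@H](CO)[C@@H](O)[C@H]2O)n2ncnc(N)c12` gives 20 nM. Compound 2 `CCCCC#Cc1cc([C@@H]2O[C@H](CO)[C@@H](O)[C@H]2O)n2ncnc(N)c12` gives 200 nM. Compound 3 `Nc1ncnn2c([C@@H]3O[C@H](CO)[C@@H](O)[C@H]3O)cc(C#Cc3cccs3)c12` gives 50100 nM. Compound 2 stands second highest of the three numbers: its nearest neighbour is compound 1, a step of a 10-fold higher number from compound 1 to compound 2 (1.00 log units; beyond the scatter), and its furthest is compound 3, a step of a 250-fold higher number from compound 2 to compound 3 (2.40 log units; beyond the scatter).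

The open question is compound 4 `Nc1ncnn2c([C@@H]3O[C@H](CO)[C@@H](O)[C@H]3O)cc(-c3ccccc3F)c12`. Its change from compound 2 is 2-fluorophenyl in place of hex-1-yn-1-yl on an aromatic carbon: the hex-1-yn-1-yl chain, with its 1 triple bond outside aromatic rings, is removed and a 2-fluorophenyl, one six-membered aromatic ring of carbon only, is attached directly at the same aromatic carbon.

Among the measured compounds shown here, no measured step makes exactly this change. For the measured compounds named here, the steps that bear on it are those that put an aromatic ring onto the triple-bonded carbon: a 2500-fold higher number from compound 1 to compound 3 (3.40 log units; beyond the scatter) and a 250-fold higher number from compound 2 to compound 3 (2.40 log units; beyond the scatter), both large and both toward a higher number. Compound 4 goes further, removing the triple bond altogether, so nothing here speaks for a return toward the numbers of compound 1 or compound 2.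

The expected step in this assay is therefore a 100-fold higher number from compound 2 to compound 4 (2.00 log units; beyond the scatter), a large rise, because a 250-fold higher number from compound 2 to compound 3 (2.40 log units; beyond the scatter) already shows an aromatic ring at this position costing most of the activity. Compound 4 is estimated at 20000 nM, within a range of 2000 nM to 100000 nM.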

Compound 4, half-maximal inhibitory concentration: 95300 nM
Estimate against measurement, compound 4: 4.8-fold (0.68 log units) below, within the range that was stated.
By their numbers in this assay, from the lowest: compound 1; then compound 2; then compounds 3 and 4 (each within the scatter of the next).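

In this assay attaching 2-fluorophenyl directly at this aromatic carbon gives a 480-fold higher number from compound 2 to compound 4 (2.68 log units; beyond the scatter) in place of hex-1-yn-1-yl and a 4800-fold higher number from compound 1 to compound 4 (3.68 log units; beyond the scatter) in place of pent-1-yn-1-yl, so the high numbers are not confined to an aromatic ring carried on a triple bond. Set against 2-(thiophen-2-yl)ethynyl, the same position gives a 1.9-fold higher number from compound 3 to compound 4 (0.28 log units; within the scatter) and the two aromatic groups cannot be told apart here, although that step changes both the ring and the triple bond. Across the four compounds, the low numbers belong only to compound 1 and compound 2, the two with a saturated chain on the triple bond, and no compound goes against this.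

No measurement at hand accounts for these steps.

The compounds shown leave open whether the triple bond matters in itself, a question that a hexyl chain attached directly at this carbon would address. They also leave open how far the low numbers survive a polar end on the chain, such as an amine or a carboxylic acid at the end of pent-1-yn-1-yl.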